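Fluoro Added to the Pyridinyl Ring of Compound 3

This account rests on a few compounds, and the source may have more. Where it says the series, first, only, none or still open, it means among the compounds named here.

Compound 1, `CCCCc1nc(=O)c(S(=O)(=O)c2ccc(-c3ccnc(NC(=O)C4CC4)c3)cc2)c(O)n1-c1c(OC)cccc1OC`: 72%
Compound 2, `CCCCc1nc(=O)c(S(=O)(=O)c2ccc(-c3ccc(F)cc3)cc2)c(O)n1-c1c(OC)cccc1OC`: 47%
Compound 3, `CCCCc1nc(=O)c(S(=O)(=O)c2ccc(-c3cccnc3)cc2)c(O)n1-c1c(OC)cccc1OC`: 57%

Of the compounds shown here, three sharing one core have been measured in an ADME assay on microsomes from liver (Mus musculus) for metabolic stability, using NADPH, with a stated time of 10 min; a higher number here means that more of the compound is left, a lower number that less of the compound is left. Compound 3 gives 57%, the second highest of the three numbers. The step of a number 15 percentage points lower from compound 1 to compound 3 (beyond the scatter) lies beyond the scatter, whereas the step of a number 10 percentage points higher from compound 2 to compound 3 (within the scatter) lies within it, so compound 3 and compound 2 cannot be told apart on this assay.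

Compound 4, `CCCCc1nc(=O)c(S(=O)(=O)c2ccc(-c3ccc(F)nc3)cc2)c(O)n1-c1c(OC)cccc1OC`, differs from compound 3 by fluoro in place of hydrogen on an aromatic carbon. Among the compounds with values here, no measured step adds a fluoro to a ring that already carries a nitrogen. The closest guide is a number 10 percentage points higher from compound 2 to compound 3 (within the scatter), where a 4-fluorophenyl gave way to a pyridin-3-yl and the number stayed within the scatter; compound 4 carries both a fluoro and the ring nitrogen. The steps of a number 25 percentage points lower from compound 1 to compound 2 (beyond the scatter) and a number 15 percentage points lower from compound 1 to compound 3 (beyond the scatter) concern the loss of the larger amide-bearing group, which is absent from both compound 3 and compound 4, so they say little here. The step of a number 2 percentage points lower from compound 3 to compound 4 (within the scatter) is therefore expected to stay within the scatter. Compound 4 is estimated at 55%, with a range from 35% to 75%.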

Compound 4, percent of the compound remaining: 69%
The estimate for compound 4 lay 14 percentage points below the measured number; low and high end bracket the measured number.
By their numbers in this assay, from the lowest: compounds 2 and 3 (each within the scatter of the next); then compounds 4 and 1 (each within the scatter of the next).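

In this assay, the step of a number 12 percentage points higher from compound 3 to compound 4 (beyond the scatter) shows that one fluoro on the pyridin-3-yl ring, next to the ring nitrogen, is enough to move the number beyond the scatter. The step of a number 22 percentage points higher from compound 2 to compound 4 (beyond the scatter) also lies beyond the scatter, so 6-fluoropyridin-3-yl can be told apart from 4-fluorophenyl, which pyridin-3-yl could not. The step of a number 3 percentage points lower from compound 1 to compound 4 (within the scatter) lies within the scatter, so this small change leaves compound 4 level with compound 1 and its much larger amide-bearing group, though nothing available here explains the result.

From the compounds shown here alone, whether this is specific to fluoro remains open, as chloro, methyl or an amine at the same place could give a different number. The compounds shown also cannot tell whether a fluoro elsewhere on the ring would act alike.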